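Working notes: amide linker in place of benzyl ether

This account rests on a few compounds, and the source may have more. Where it says the series, first, only, none or still open, it means among the compounds named here.

Measured in a functional assay on HEK293 cells for agonist activity at G-protein coupled receptor 39 (Homo sapiens), read by scintillation proximity assay and inositol phosphate accumulation, with a stated time of 75 min; a higher number here means that more compound is needed for the effect, a lower number that less compound is needed:
- compound 1 `Cc1nn(-c2ncnc3nc[nH]c23)c2c1C(OCc1ccccc1F)CC(=O)N2` gives 78 nM
- compound 2 `CCCCCCCCOC1CC(=O)Nc2c1c(C)nn2-c1ncnc2nc[nH]c12` gives 388 nM
- compound 3 `Cc1nn(-c2ncnc3nc[nH]c23)c2c1C(OCc1ccc(F)cc1)CC(=O)N2` gives 126 nM

All three share one core and differ only in the group attached through the oxygen on the saturated ring carbon. Compound 3 stands second highest of the three numbers: its nearest neighbour is compound 1, a gap within the scatter (a 1.6-fold higher number from compound 1 to compound 3 (0.21 log units; within the scatter)), while the gap to compound 2 is beyond it (a 3.1-fold lower number from compound 2 to compound 3 (0.49 log units; beyond the scatter)). The one clear finding so far is that a heptyl chain costs potency against either fluorophenyl (a 5.0-fold higher number from compound 1 to compound 2 (0.70 log units; beyond the scatter)).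

Compound 4 `Cc1nn(-c2ncnc3nc[nH]c23)c2c1C(NC(=O)c1ccccc1)CC(=O)N2` is the next candidate. The change is benzamido in place of (4-fluorobenzyl)oxy on a saturated ring carbon. Among the measured compounds shown here, no measured step bears on it directly: every earlier step kept the ether oxygen and varied only what hangs from the methylene, whereas here the linker itself changes, with a hydrogen-bond donor entering. For the measured compounds named here, the two aryl ethers agree within the scatter, and the only beyond-scatter step replaced aryl with alkyl, so the aryl ring of compound 4 is retained but its connection is new. With nothing closer to lean on, a modest loss is expected, uncertainly: compound 4 is estimated at 300 nM, with a wide range from 70 nM to 1500 nM. The expected step is a 2.4-fold higher number from compound 3 to compound 4 (0.38 log units; beyond the scatter).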

Compound 4, half-maximal effective concentration: 158 nM
The estimate for compound 4 lay 1.9-fold (0.28 log units) above the measured number, within the range that was stated.
By their numbers in this assay, from the lowest: compounds 1, 3 and 4 (each within the scatter of the next, the first and the last beyond it); then compound 2.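

The linker on the saturated ring carbon can be changed without a clear shift in this pair: benzamido brings in the amide hydrogen as a hydrogen-bond donor, and the step is a 1.3-fold higher number from compound 3 to compound 4 (0.10 log units; within the scatter) and so gives no order between the two. Benzamido also keeps the advantage over the alkyl ether, with a 2.5-fold lower number from compound 2 to compound 4 (0.39 log units; beyond the scatter) as the gain, so an aromatic ring is favoured over octyloxy with either an ether or an amide linker, while a 2.0-fold higher number from compound 1 to compound 4 (0.31 log units; beyond the scatter) sets the amide apart from the (2-fluorobenzyl)oxy compound, even though compound 1 and compound 3 lie within the scatter of each other. No data in hand explain these steps.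

Benzamido differs from both aryl ethers in more than the linker, since its ring carries no fluorine, so a 4-fluorobenzamido group would be needed to separate the linker from the fluorine. Also open, from the compounds shown here alone, is how far this position tolerates other connections, such as a benzylamino group or an acetamido group without the aromatic ring.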